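Aryl amide variation on a shared flavonol core

This account rests on a few compounds, and the source may have more. Where it says the series, first, only, none or still open, it means among the compounds named here.

Three compounds share a core, shown for compound 1 as `O=C(Nc1cccc(-c2oc3cc(-c4ccc(F)cc4)ccc3c(=O)c2O)c1)c1ccc(F)cc1F`, and differ only in the aryl group on the carbonyl carbon of the amide. In a functional assay on HeLa cells (Homo sapiens) for antiproliferative activity, read by CCK-8 assay, with a stated time of 72 h (on this read-out lower numbers stand for stronger inhibition and higher numbers for weaker inhibition), compound 1 gives 10700 nM. Compound 2, `COc1cccc(C(=O)Nc2cccc(-c3oc4cc(-c5ccc(F)cc5)ccc4c(=O)c3O)c2)c1`, gives 5650 nM in this assay, a change of a 1.9-fold lower number from compound 1 to compound 2 (0.28 log units; within the scatter). Compound 3, `COc1ccc(C(=O)Nc2cccc(-c3oc4cc(-c5ccc(F)cc5)ccc4c(=O)c3O)c2)c(F)c1`, gives 16100 nM in this assay and so carries the highest number of the three: the two steps that lead to it are a 1.5-fold higher number from compound 1 to compound 3 (0.18 log units; within the scatter) and a 2.8-fold higher number from compound 2 to compound 3 (0.45 log units; beyond the scatter).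

Compound 4, `O=C(Nc1cccc(-c2oc3cc(-c4ccc(F)cc4)ccc3c(=O)c2O)c1)c1ccc(Cl)nc1`, is not yet measured. It differs from compound 3 by 6-chloropyridin-3-yl in place of 2-fluoro-4-methoxyphenyl on a carbonyl carbon. Going by the values given here, the steps that bear on this change are the two aryl swaps on the carbonyl carbon, a 1.9-fold lower number from compound 1 to compound 2 (0.28 log units; within the scatter) and a 2.8-fold higher number from compound 2 to compound 3 (0.45 log units; beyond the scatter), one within the scatter and one modestly beyond it. Swapping the aryl group therefore moves the number only a little in either direction. Since compound 3 already sits at the high end, a step toward the middle of the measured spread is expected, of about a 1.7-fold lower number from compound 3 to compound 4 (0.23 log units; within the scatter), though a step within the scatter is just as plausible. The estimate for compound 4 in this assay is 9500 nM, with a range from 3500 nM to 26000 nM.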

Compound 4, half-maximal inhibitory concentration: 4080 nM
Compound 4: middle estimate off by 2.3-fold (0.37 log units), on the high side; low and high end bracket the measured number.
By their numbers in this assay, from the lowest: compounds 4, 2, 1 and 3 (each within the scatter of the next, the first and the last beyond it).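

In this assay, going by these compounds alone, compound 4 adds two steps beyond the scatter at this position, a 3.9-fold lower number from compound 3 to compound 4 (0.60 log units; beyond the scatter) and a 2.6-fold lower number from compound 1 to compound 4 (0.42 log units; beyond the scatter), where the earlier compounds had given only one such step. A ring with a hetero atom on the carbonyl carbon is therefore compatible with the low end of the measured spread, and the lower numbers here do not depend on an aromatic ring of carbon only. At the same time, a 1.4-fold lower number from compound 2 to compound 4 (0.14 log units; within the scatter) stays within the scatter, so the 6-chloropyridin-3-yl and 3-methoxyphenyl groups cannot be told apart in this assay, even though they differ in ring type and substituent.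

Nothing available here accounts for the differences among these aryl groups. The compounds shown also leave open whether the chlorine or the ring nitrogen carries the step, which a plain pyridin-3-yl group on the same carbonyl carbon would help to separate, and whether a non-aromatic group such as morpholine or a simple alkyl chain would be accepted there at all.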